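The source may hold more compounds than are shown below. What is called first, only, known or untested is meant among the compounds shown, and "the series" means these compounds.

Measured compounds in a functional assay on HCT-116 cells (Homo sapiens) for antiproliferative activity, read by MTT assay, with a stated time of 24 h; on this read-out higher numbers stand for weaker inhibition and lower numbers for stronger inhibition:
- compound 1 `COC1=C(OC)C(O)(CCn2cc(-c3ccccc3)nn2)NC1=O`: 46300 nM
- compound 2 `O=C1NC(O)(CCn2cc(Cc3ccccc3)nn2)C(OCc2ccccc2)=C1OCc1ccccc1`: 51200 nM
- compound 3 `O=C1O/C(=C\Cn2cc(C3=CCCCC3)nn2)C(OCc2ccccc2)=C1OCc1ccccc1`: reported only as a limit, > 100000 nM

Compound 1 and compound 2 share the hydroxylated, nitrogen-containing core with a triazole-linked side chain; in this assay their numbers lie within the scatter of each other, so no order can be read between them. Compound 3, which carries the lactone variant of the core with an exocyclic double bond, returns a limit rather than a number in this assay (the limit of > 100000 nM in this assay, at which 1 of the 3 values shown sits); it cannot be set against the others beyond stating that it is a limit.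

The next compound, compound 4 `COC1=C(OC)C(O)(CCn2cc(-c3ccc(C(C)(C)C)cc3)nn2)NC1=O`, keeps the core and the triazole of compound 1 and changes only the phenyl substituent: tert-butyl in place of hydrogen on an aromatic carbon. For the measured compounds named here, no measured pair in this set isolates such a change, so there is no step to lean on. The expectation in this assay is a step from compound 1 to compound 4 of a 1.3-fold lower number from compound 1 to compound 4 (0.12 log units; within the scatter), not clearly beyond the scatter in either direction. Compound 4 is therefore estimated at 35000 nM in this assay, with the expected range running from 12000 nM to 100000 nM.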

Compound 4, half-maximal inhibitory concentration: 50300 nM
The estimate for compound 4 lay 1.4-fold (0.16 log units) below the measured number; the measured number falls inside the stated range.
By their numbers in this assay, from the lowest: compounds 1, 4 and 2 (each within the scatter of the next). At a limit, above all of these: compound 3.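

In this assay, for the compounds shown here, tert-butyl in place of hydrogen on an aromatic carbon, para to a large group, provides the first single-place comparison: the step is a 1.1-fold higher number from compound 1 to compound 4 (0.04 log units; within the scatter) and stays within the usual scatter. The earlier compounds shown here could not show this, as none of them forms a pair that differs in one place. On this read-out, the six-membered aromatic ring can therefore carry tert-butyl at this carbon with no change that can be told from the scatter, although this is a single substitution on a single core and no wider pattern follows from it. Nothing in the available data explains this flat step.

Going by these compounds, whether an amine, a carboxylic acid or a longer chain on the same aromatic carbon would move the number beyond the scatter remains open. Also open, on these data alone, is whether tert-butyl would give a similar step on the core of compound 2, which differs from compound 1 in more than one place and so offers no direct comparison.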